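A few compounds are considered here, and "the series" means these few. Any claim that something is new, unique, unknown or untested is made for them only; others in the source may bear on it.

Measured in an assay for binding affinity to metabotropic glutamate receptor 5 (Rattus norvegicus); a higher number here means a weaker inhibitor, a lower number a stronger inhibitor:
Compound 1, `Nc1ccccc1-c1cc(F)cc(-n2nnc(-c3ccccn3)n2)c1`, gives 7 nM.
Compound 2, `Cc1ccncc1-c1cc(F)cc(-n2nnc(-c3ccccn3)n2)c1`, gives 2 nM.
Compound 3, `Cc1ccc(-c2cc(F)cc(-n3nnc(-c4ccccn4)n3)c2)cn1`, gives 36 nM.

Compound 3 stands at the highest of the three numbers, that is, it is the weakest inhibitor of the set. Compound 4, `Nc1cccnc1-c1cc(F)cc(-n2nnc(-c3ccccn3)n2)c1`, differs from compound 3 in one place: 3-aminopyridin-2-yl in place of 6-methylpyridin-3-yl on an aromatic carbon. Two of the measured steps bear on this change, both ending at compound 3. The step of a 5.1-fold higher number from compound 1 to compound 3 (0.71 log units; beyond the scatter) shows that exchanging the 2-aminophenyl of compound 1 for the 6-methylpyridin-3-yl of compound 3 gave a weaker inhibitor, and the step of an 18-fold higher number from compound 2 to compound 3 (1.26 log units; beyond the scatter) shows an even larger loss when the 4-methylpyridin-3-yl of compound 2 was exchanged for the same group. Compound 4 carries both an amino group, as compound 1 does, and a pyridine ring, as compound 2 does, so reversing the change out of the 6-methylpyridin-3-yl of compound 3 is expected to bring the number back down. The step from compound 3 is therefore expected to be a 7.2-fold lower number from compound 3 to compound 4 (0.86 log units; beyond the scatter), a lowering clearly beyond the scatter. Compound 4 is estimated at 5 nM in this assay, with a range from 1.5 nM to 15 nM.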

Compound 4, inhibition constant: 31 nM
Compound 4: the middle estimate sits 6.2-fold (0.79 log units) below what was measured, outside the stated range (above it).
By their numbers in this assay, from the lowest: compound 2; then compound 1; then compounds 4 and 3 (each within the scatter of the next).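

In this assay, replacing the 6-methylpyridin-3-yl group with the 3-aminopyridin-2-yl group gave a 1.2-fold lower number from compound 3 to compound 4 (0.06 log units; within the scatter), so having an amino group and a pyridine ring in one substituent did not restore the low numbers of the compounds that have only one of these features. The amino-bearing aryl groups are not interchangeable here: the change in ring alone gave a 4.4-fold higher number from compound 1 to compound 4 (0.65 log units; beyond the scatter), and the comparison with the methylpyridine gave a 16-fold higher number from compound 2 to compound 4 (1.19 log units; beyond the scatter), which leaves the 4-methylpyridin-3-yl group of compound 2 well ahead of the 3-aminopyridin-2-yl group at this position. Nothing available accounts for these differences.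

Going by these compounds, what remains open is whether the low number of compound 2 depends on its methyl group, its ring nitrogen or the two together, a question that a plain pyridin-3-yl group and a 2-methylphenyl group at this position could help separate. On these data alone, it is also open whether a methyl or hydroxyl group in place of the amino group of compound 4 would move the number in this assay.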